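An Aryl Swap on the Triazole Nitrogen

This account rests on a few compounds, and the source may have more. Where it says the series, first, only, none or still open, it means among the compounds named here.

compound 1 `COc1ccccc1-n1cc(COc2c(/C=C\C(=O)O)ccc(OC)c2CC=C(C)C)nn1` — 43000 nM
compound 2 `COc1ccc(/C=C\C(=O)O)c(OCc2cn(-c3ccccc3F)nn2)c1CC=C(C)C` — "not determined" (no result reported)
compound 3 `COc1ccc(/C=C\C(=O)O)c(OCc2cn(-c3cccc(C#N)c3)nn2)c1CC=C(C)C` — "not determined" (no result reported)

Within the data shown here, in a functional assay on A549 cells (Homo sapiens) for cytotoxicity, read by MTT assay, with a stated time of 24 h (on this read-out higher numbers stand for weaker inhibition and lower numbers for stronger inhibition), compound 1 gives 43000 nM, the only number in this small set. For compound 2 the entry reads "not determined" (no result reported), and for compound 3 it reads "not determined" (no result reported), so compound 3 stands without a value of its own. Compound 4 `COc1ccc(-n2cc(COc3c(/C=C\C(=O)O)ccc(OC)c3CC=C(C)C)nn2)cc1` differs from compound 3 by 4-methoxyphenyl in place of 3-cyanophenyl on an aromatic nitrogen. Among the measured compounds shown here, no step between measured compounds speaks to this change, and the single reading of compound 1 in this assay offers the only anchor; on that basis no shift beyond the usual scatter is expected in this assay, and weak inhibition remains the likely outcome. Compound 4 is therefore expected to give about 45000 nM, with a range from 15000 nM to 150000 nM.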

Compound 4, half-maximal inhibitory concentration: 10200 nM
Compound 4: middle estimate off by 4.4-fold (0.64 log units), on the high side, outside the stated range (below it).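

With 4-methoxyphenyl in place of 2-methoxyphenyl on the aromatic nitrogen, this assay records a 4.2-fold lower number from compound 1 to compound 4 (0.62 log units; beyond the scatter) and so shows that where the methoxy group stands on this aryl ring can alone move the read-out beyond the scatter. Steps involving compound 2 or compound 3 cannot be read, as neither has a value. No measured evidence accounts for this step.

Still open, on these data alone, is how 3-methoxyphenyl would read at this position. Also open, as far as these compounds go, is whether an amine or a longer ethoxy chain on the same aryl ring would give a similar number.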